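Aromatic Ring Swapped for Saturated Ring: Compound 4 Expected

This account rests on a few compounds, and the source may have more. Where it says the series, first, only, none or still open, it means among the compounds named here.

Compound 1, `Nc1ccccc1NC(=O)c1ccc(CSC(=S)N2CCN(c3cccnc3)CC2)cc1`: 27.6%
Compound 2, `Nc1ccccc1NC(=O)c1ccc(CSC(=S)N2CCN(c3ncccn3)CC2)cc1`: 28.4%
Compound 3, `Nc1ccccc1NC(=O)c1ccc(CSC(=S)N2CCN(c3ccccc3F)CC2)cc1`: 33.7%

These three compounds share one core and differ only in the group carried on an amine nitrogen in a ring. All were tested in a functional assay on MGC-803 cells (Homo sapiens) for antiproliferative activity, read by CCK-8 assay, with a stated time of 72 h, tested at 2 uM; on this read-out lower numbers stand for a weaker effect and higher numbers for a stronger effect at the one concentration tested. The steps between them are small: a number 0.8 percentage points higher from compound 1 to compound 2 (within the scatter), a number 6.1 percentage points higher from compound 1 to compound 3 (within the scatter) and a number 5.3 percentage points higher from compound 2 to compound 3 (within the scatter). Compound 3 gives 33.7%, and the numbers of compound 1 and compound 2 both lie within the scatter of that figure, so the three cannot be told apart on this read-out.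

Compound 4, `Nc1ccccc1NC(=O)c1ccc(CSC(=S)N2CCN(C3CCCCC3)CC2)cc1`, has not yet been measured. It differs from compound 3 in this way: cyclohexyl in place of 2-fluorophenyl on an amine nitrogen in a ring. Here an aromatic ring leaves and a non-aromatic ring enters, whereas every measured step exchanged one aromatic ring for another. For the measured compounds named here, no measured step therefore bears directly on this change; the only guidance is that three different groups at this position gave numbers within the scatter of each other. On that basis no step beyond the scatter is expected in this assay, and the estimated step is a number 3.7 percentage points lower from compound 3 to compound 4 (within the scatter). Compound 4 is expected to give 30%, with a range from 15% to 45%.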

Compound 4, a percentage reported as inhibition, at one concentration (the size of the read-out at that concentration, not a potency): 16.9%
Estimate against measurement, compound 4: 13.1 percentage points above, within the range that was stated.
By their numbers in this assay, from the lowest: compound 4; then compounds 1, 2 and 3 (each within the scatter of the next).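

In this assay the three aromatic groups could not be told apart, but cyclohexyl on the amine nitrogen does separate from them, with a number 16.8 percentage points lower from compound 3 to compound 4 (beyond the scatter) and a number 11.5 percentage points lower from compound 2 to compound 4 (beyond the scatter) and also a number 10.7 percentage points lower from compound 1 to compound 4 (beyond the scatter) on the same read-out. So this position is not indifferent to every group it carries: all three steps are modest but lie beyond the scatter, and each replaces an aromatic ring with a non-aromatic one, the first change of that kind among these compounds. Nothing measured here explains why the number falls with this swap.

Compound 4 is the only compound shown with a non-aromatic ring at this position, so it remains open whether the lower number belongs to non-aromatic rings in general or to cyclohexyl alone. A smaller ring such as cyclopentyl, a ring holding oxygen such as tetrahydropyran-4-yl, an open chain such as n-hexyl, or a benzyl group, which sets a carbon between the ring and the amine nitrogen, would each help to separate these possibilities.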